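Cytotoxicity notes: the step from compound 3 to compound 4

A few compounds are considered here, and "the series" means these few. Any claim that something is new, unique, unknown or untested is made for them only; others in the source may bear on it.

In a functional assay on C8166 cells (Homo sapiens) for cytotoxicity, read by MTT assay (a higher number here means that more compound is tolerated, a lower number that less compound is tolerated), compound 3 (`Cc1cc(S(N)(=O)=O)ccc1NC(=O)COc1ccc(Cl)cc1NC(=O)c1cc(Cl)ccc1Cl`) gives 42100 nM and compound 2 (`Cc1cc(S(N)(=O)=O)ccc1NC(=O)COc1ccc(Cl)cc1NC(=O)c1ccc(Cl)cc1Cl`) gives 61100 nM within the scatter of it (a 1.5-fold lower number from compound 2 to compound 3 (0.16 log units; within the scatter)). Compound 1 (`Cc1cc(S(N)(=O)=O)ccc1NC(=O)COc1ccc(Cl)cc1NC(=O)c1ccccc1`) gives 207000 nM as the highest number of the three. Compound 4 (`Cc1cc(S(N)(=O)=O)ccc1NC(=O)COc1ccc(Cl)cc1NC(=O)c1cc(Cl)cc(C#N)c1`) carries 3-chloro-5-cyanophenyl in place of 2,5-dichlorophenyl on a carbonyl carbon. The measured steps bearing on this are modest: phenyl to 2,4-dichlorophenyl (a 3.4-fold lower number from compound 1 to compound 2 (0.53 log units; beyond the scatter)) and phenyl to 2,5-dichlorophenyl (a 4.9-fold lower number from compound 1 to compound 3 (0.69 log units; beyond the scatter)). Among the measured compounds shown here, no measured compound carries a nitrile, so the direction is uncertain. No change beyond the scatter is expected (a 1.3-fold higher number from compound 3 to compound 4 (0.12 log units; within the scatter)). The estimated value for compound 4 is 55000 nM (expected range 25000 nM to 130000 nM).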

Compound 4, half-maximal cytotoxic concentration: 131000 nM
For compound 4 the middle estimate is 2.4-fold (0.38 log units) below the measured one; measured number outside the range, above it.
By their numbers in this assay, from the lowest: compounds 3 and 2 (each within the scatter of the next); then compounds 4 and 1 (each within the scatter of the next).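

On the carbonyl carbon, 3-chloro-5-cyanophenyl gives a higher number than either dichlorophenyl group in this assay: a 3.1-fold higher number from compound 3 to compound 4 (0.49 log units; beyond the scatter) and a 2.1-fold higher number from compound 2 to compound 4 (0.33 log units; beyond the scatter). Against plain phenyl the change stays within the scatter, a 1.6-fold lower number from compound 1 to compound 4 (0.20 log units; within the scatter), so substitution on this ring does not by itself lower the number, and compound 4 goes against any such reading of compounds 2 and 3.

Going by these compounds, whether the nitrile or the placement of the chlorine carries the step stays open, as does the effect of an amine or a carboxylic acid in place of the nitrile. No measurement shown accounts for the step.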